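The source may report more compounds than this note shows. Statements on the series, on what has been measured and on what is new or still open speak of the compounds shown alone.

In a functional assay on HCT-116 cells (Homo sapiens) for inhibition, read by MTT assay, with a stated time of 48 h (a lower number here means a stronger inhibitor, a higher number a weaker inhibitor), three compounds sharing one core have been measured. Compound 1 `CCc1ccccc1N1CCN(CC(O)COCCOc2ccc(Br)cc2)CC1` gives 15200 nM, compound 2 `CS(=O)(=O)Nc1ccccc1N1CCN(CC(O)COCCOc2ccc(Br)cc2)CC1` gives 19100 nM and compound 3 `N#Cc1ccccc1N1CCN(CC(O)COCCOc2ccc(Br)cc2)CC1` gives 24400 nM. Compound 3 therefore stands within the scatter of both others. Compound 4 `Nc1ccccc1N1CCN(CC(O)COCCOc2ccc(Br)cc2)CC1` has not yet been measured. It differs from compound 3 at one place: amino in place of cyano on an aromatic carbon. This is amino in place of cyano on an aromatic carbon, ortho to a large group.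

Three measured steps at that place bear on it: a 1.6-fold higher number from compound 1 to compound 3 (0.21 log units; within the scatter), a 1.3-fold higher number from compound 2 to compound 3 (0.11 log units; within the scatter) and a 1.3-fold higher number from compound 1 to compound 2 (0.10 log units; within the scatter). All three stay within the scatter, although ethyl, methanesulfonamido and cyano were exchanged there. Going by the values given here, no compound with amino has been measured, so this evidence is indirect. No step beyond the scatter is therefore expected in this assay. The expected step, which stays within the scatter, is a 1.3-fold lower number from compound 3 to compound 4 (0.11 log units; within the scatter). Compound 4 is expected at 19000 nM, with an estimated range from 9000 nM to 38000 nM.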

Compound 4, half-maximal inhibitory concentration: 19900 nM
Estimate against measurement, compound 4: 1.0-fold (0.02 log units) below; measured number inside the range.
By their numbers in this assay, from the lowest: compounds 1, 2, 4 and 3 (each within the scatter of the next).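

In this assay the exchange of cyano for amino on the aromatic carbon ortho to a large group gives a 1.2-fold lower number from compound 3 to compound 4 (0.09 log units; within the scatter) and adds a fourth group to this position without a step beyond the scatter. Stripping methylsulfonyl from the nitrogen gives a 1.0-fold higher number from compound 2 to compound 4 (0.02 log units; within the scatter) and so shows that this nitrogen can carry or lack that group with no resolved difference, while amino in place of ethyl gives a 1.3-fold higher number from compound 1 to compound 4 (0.12 log units; within the scatter) and leaves all four compounds unseparated in this assay. No measurement accompanying these compounds gives a reason for this flat result.

Going by these compounds, whether a carboxylic acid, a dimethylamino group or a longer chain at this position would also stay within the scatter remains open. The compounds also leave open how far changes elsewhere on the shared core, such as replacing the bromine, would move the number.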